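This account rests on a few compounds, and the source may have more. Where it says the series, first, only, none or still open, it means among the compounds named here.

In a functional assay on HCT-116 cells (Homo sapiens) for antiproliferative activity, read by sulforhodamine B assay, with a stated time of 72 h (on this read-out lower numbers stand for stronger inhibition and higher numbers for weaker inhibition), compound 1 `Cn1ncc(Cl)c1-c1cc(C(=O)N[C@@H]2CN[C@H](CC(O)CO)C[C@H]2c2ccc(Cl)c(Cl)c2)oc1Cl` gives 1110 nM, compound 2 `Cn1ncc(Cl)c1-c1cc(C(=O)N[C@@H]2CN[C@H](CCN3CCCCC3)C[C@H]2c2ccc(Cl)c(Cl)c2)oc1Cl` gives 1020 nM and compound 3 `Cn1ncc(Cl)c1-c1cc(C(=O)N[C@@H]2CN[C@H](CC(N)=O)C[C@H]2c2ccc(Cl)c(Cl)c2)oc1Cl` gives 650 nM, so compound 3 stands within the scatter of both others. Compound 4 `CN(C)CC[C@@H]1C[C@@H](c2ccc(Cl)c(Cl)c2)[C@H](NC(=O)c2cc(-c3c(Cl)cnn3C)c(Cl)o2)CN1` has (dimethylamino)methyl in place of carbamoyl on a saturated chain carbon bound to a saturated ring carbon. The closest guide is a 1.6-fold lower number from compound 2 to compound 3 (0.20 log units; within the scatter), which removes a similar amine-bearing group, while a 1.1-fold lower number from compound 1 to compound 2 (0.04 log units; within the scatter) and a 1.7-fold lower number from compound 1 to compound 3 (0.23 log units; within the scatter) are also small. Reversing that closest step suggests a slightly higher number in this assay, with no change expected beyond the scatter. The expected step is a 1.4-fold higher number from compound 3 to compound 4 (0.14 log units; within the scatter). Compound 4 is estimated at 900 nM with 420 nM to 1900 nM as the expected range.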

Compound 4, half-maximal inhibitory concentration: 1710 nM
The estimate for compound 4 lay 1.9-fold (0.28 log units) below the measured number, within the range that was stated.
By their numbers in this assay, from the lowest: compounds 3, 2, 1 and 4 (each within the scatter of the next, the first and the last beyond it).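

Within this assay, this place on a saturated chain carbon bound to a saturated ring carbon now gives its first step beyond the scatter, though a modest one (a 2.6-fold higher number from compound 3 to compound 4 (0.42 log units; beyond the scatter)), for (dimethylamino)methyl in place of carbamoyl. The other two steps stay within the scatter (a 1.7-fold higher number from compound 2 to compound 4 (0.22 log units; within the scatter); a 1.5-fold higher number from compound 1 to compound 4 (0.19 log units; within the scatter)), so dimethylamino, piperidin-1-yl and 1,2-dihydroxyethyl ends are not told apart here. No measurement shown explains the step away from carbamoyl.

Going by these compounds, it remains open whether a carboxylic acid here would track with the carbamoyl compound or with the amines. A longer chain ending in carbamoyl is also untested among the compounds shown.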